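Thiosemicarbazones: Exchanging the Phenoxy Ring and Lipophilicity

The compounds below may be only part of what the source reports. "The series", "measured", "known", "first", "only" and "open" are said of these compounds alone.

Measured so far in a physicochemical assay for lipophilicity, in phosphate buffer, measured as octanol-water partition, with a stated time of 24 h; a higher number here means a more lipophilic compound, a lower number a more polar compound:
compound 1, `Cc1cc(Oc2ccc(/C=N/NC(=S)Nc3ccc(F)cc3)cc2)ccc1Cl`, gives 6.07
compound 2, `Fc1ccc(NC(=S)N/N=C/c2ccc(Oc3ccc(F)cc3)cc2)cc1`, gives 5.19
compound 3, `Cc1cc(Oc2ccc(/C=N/NC(=S)Nc3ccccc3)cc2)ccc1Cl`, gives 6.03

Compound 1 and compound 3 share a core that differs only at the aryl group on the thiourea nitrogen, a difference counted as hydrogen in place of fluoro on an aromatic carbon; in this assay the two compounds sit within the scatter of each other, with a step of a number 0.04 log units lower from compound 1 to compound 3 (within the scatter), so no order between them can be claimed.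

The change of interest is the exchange of the phenoxy ring. From compound 1 to compound 2 it is counted as 4-fluorophenyl in place of 4-chloro-3-methylphenyl on an oxygen on an aromatic ring, and it made a step of a number 0.88 log units lower from compound 1 to compound 2 (beyond the scatter), beyond the scatter. Compound 4, `Fc1ccc(Oc2ccc(/C=N/NC(=S)Nc3ccccc3)cc2)cc1`, has not yet been measured in this assay. It stands to compound 3 exactly as compound 2 stands to compound 1: the difference is 4-fluorophenyl in place of 4-chloro-3-methylphenyl on an oxygen on an aromatic ring, the same change at the same place.

For the measured compounds named here, because the single measured instance of this change gave a number 0.88 log units lower from compound 1 to compound 2 (beyond the scatter), the account expects a step of comparable size, a number 0.88 log units lower from compound 3 to compound 4 (beyond the scatter), from compound 3 to compound 4 in this assay. That expectation rests on one pair alone and on the near-identity of compound 1 and compound 3 in this assay. Compound 4 is therefore estimated at 5.15, with a range from 4.8 to 5.5.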

Compound 4, partition coefficient: 5.09
Estimate against measurement, compound 4: 0.06 log units above; low and high end bracket the measured number.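

In this assay, the exchange of 4-chloro-3-methylphenyl for 4-fluorophenyl on the oxygen gave a step of a number 0.94 log units lower from compound 3 to compound 4 (beyond the scatter), in the same direction as the earlier step of a number 0.88 log units lower from compound 1 to compound 2 (beyond the scatter), so the change carried from the core of compound 1 to the core of compound 3 in both sign and rough size. The two products of the exchange also remain close, with a step of a number 0.10 log units lower from compound 2 to compound 4 (within the scatter), so no order between them can be claimed. This shows transfer only across two closely related cores, which differ by a single fluoro on an aromatic carbon, and it cannot establish that the change would behave the same way on a more different core; nothing given here bears on why the exchange moves the number as it does.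

The compounds shown leave open how much of the step belongs to the chloro and how much to the methyl, since the two leave together in each exchange. They also leave open whether the same regularity would hold if an amine or a carboxylic acid were carried on the ring attached to the oxygen, or on the aryl group of the thiourea nitrogen.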